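This account rests on a few compounds, and the source may have more. Where it says the series, first, only, none or still open, it means among the compounds named here.

Compound 1 `Nc1ncnc2c1ncn2[C@@H]1O[C@H](CSCCCC(=O)O)[C@@H](O)[C@H]1O` has no result in this set: in an assay for inhibition of tRNA (cytosine(38)-C(5))-methyltransferase (Homo sapiens), with a stated time of 5 min, tested at 100 uM (a higher number here means more inhibition at the concentration tested (going by the name of the read-out), a lower number less inhibition), compound 1 shows no result reported. Among the compounds with values here, compound 2 `Nc1ncnc2c1ncn2[C@@H]1O[C@H](CN(CC[C@H](N)C(=O)O)CC2CCC2)[C@@H](O)[C@H]1O` is the only compound with a number: in this assay compound 2 gives 32%. Compound 3 `C#CC(C)(C)N(CC[C@H](N)C(=O)O)C[C@H]1O[C@@H](n2cnc3c(N)ncnc32)[C@H](O)[C@@H]1O` differs from compound 2 in one place, (1,1-dimethylprop-2-yn-1-yl in place of cyclobutylmethyl on an amine nitrogen), a change that keeps the count of heavy atoms and the absence of donors and acceptors. Within the data shown here, with no measured pair of this kind to lean on, the step from compound 2 to compound 3 is expected to stay within the scatter, at a number 2 percentage points lower from compound 2 to compound 3 (within the scatter). Compound 3 is therefore estimated at 30%, with a range from 10% to 55%.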

Compound 3, a percentage reported as inhibition, at one concentration (the size of the read-out at that concentration, not a potency): 17.3%
For compound 3 the middle estimate is 12.7 percentage points above the measured one; the range from low to high includes it.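

At the amine nitrogen, the swap of cyclobutylmethyl for 1,1-dimethylprop-2-yn-1-yl in this assay gives a number 14.7 percentage points lower from compound 2 to compound 3 (beyond the scatter). The read-out at this position therefore responds to the nature of the group even though both groups hold 5 heavy atoms, one with a four-membered ring and the other with a triple bond and no ring. No available evidence bears on the origin of this step. The compounds shown leave open whether the loss of the ring or the entry of the triple bond carries the step, and a straight pentyl chain, with neither feature, would separate the two.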